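Notes on a short cytotoxicity series

This account rests on a few compounds, and the source may have more. Where it says the series, first, only, none or still open, it means among the compounds named here.

Measured so far:
compound 1 `CC(C)=CCCC(C)/C=C/C=C(\C)C=O`: 2.5 ug/mL
compound 2 `C=C/C(C)=C\C=C\C(C)CC(=O)CC(C)C`: 2.5 ug/mL

In a functional assay on HT-29 cells (Homo sapiens) for cytotoxicity (a higher number here means a weaker inhibitor, a lower number a stronger inhibitor), compound 1 gives 2.5 ug/mL. In this assay compound 2 gives 2.5 ug/mL, level with compound 1 at the digits shown and within the scatter, so the two are treated as equal here.

Compound 3 `C=C/C(C)=C/C=C/C(C)CC(=O)CC(C)C` is the next entry. It differs from compound 2 only as follows: the two compounds have the same atoms and bonds; at least one stereo element is drawn with a configuration in one of them and without one in the other: 1 of 3 stereo elements differ; a double bond is drawn Z in compound 2 and E in compound 3. Among the compounds with values here, no measured pair shows such a change of a double bond drawn Z to one drawn E, so there is no step to lean on. Given the identical atoms and bonds, the expectation is no step beyond the scatter in this assay, that is no change at the digits printed from compound 2 to compound 3 (within the scatter). Compound 3 is expected at 2.5 ug/mL, in the range 1.2 ug/mL to 5 ug/mL.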

Compound 3, half-maximal inhibitory concentration: 5 ug/mL
Compound 3: middle estimate off by 2.0-fold (0.30 log units), on the low side; low and high end bracket the measured number.
By their numbers in this assay, from the lowest: compounds 1, 2 and 3 (each within the scatter of the next).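

The series now holds its first step for a double bond drawn Z changing to one drawn E: in this assay there is a 2.0-fold higher number from compound 2 to compound 3 (0.30 log units; within the scatter), so at this position the change does not separate the two compounds beyond the scatter. The step is read with one reservation: the fact that one of compounds 2 and 3 is drawn with a defined configuration and the other without, at the place where they differ.

Still open, going by these compounds, is whether a carboxylic acid or an amine in place of the carbonyl would shift the number beyond the scatter. Also open, on these data alone, is whether the same change at the other double bonds would leave the number as flat.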